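The compounds below may be only part of what the source reports. "The series", "measured", "known", "first", "only" and "open" are said of these compounds alone.

Working notes on the series. Of the compounds shown here, three have been measured in a functional assay on ACHN cells (Homo sapiens) for cytotoxicity, read by sulforhodamine B assay, with a stated time of 48 h, tested at 0.001 uM; a higher number here means a weaker effect of the compound at the concentration tested, a lower number a stronger effect. Compound 1 `COc1cc(C)cc(-c2c(-c3ccnc(-c4ccc(C(C)=O)cc4)c3)cnn2CC#N)c1` gives 100% in this assay. Compound 2 `COc1cc(C)cc(-c2nn(CC#N)cc2-c2ccc(-c3cccc(C(C)=O)c3)nc2)c1` gives 93%. Compound 3 `Cc1cc(O)cc(-c2nn(CC#N)cc2-c2ccnc(-c3ccc(Oc4ccccc4)cc3)c2)c1` gives 98%. The number for compound 3 lies between those of compound 1, the nearest, and compound 2, the furthest, and both of those gaps stay within the usual scatter, so the three measured compounds are not separated by this assay at the concentration used.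

Compound 4 `Cc1cc(O)cc(-c2nn(CC#N)cc2-c2ccnc(-c3ccc(N(C)C)cc3)c2)c1` has not yet been measured. It differs from compound 3 in one place: dimethylamino in place of phenoxy on an aromatic carbon. For the measured compounds named here, no step between measured compounds touches this part of the structure, so the change cannot be read against a measured pair. Given that compound 1, compound 2 and compound 3 all sit close together in this assay, the step from compound 3 to compound 4 is expected to be small, a number 1 percentage points lower from compound 3 to compound 4 (within the scatter), with no direction beyond the scatter. Compound 4 is therefore estimated at 97% in this assay, with a range from 88% to 105%.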

Compound 4, a percentage reported as activity, at one concentration (the size of the read-out at that concentration, not a potency): 94%
The estimate for compound 4 lay 3 percentage points above the measured number; low and high end bracket the measured number.
By their numbers in this assay, from the lowest: compounds 2, 4, 3 and 1 (each within the scatter of the next).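

In this assay, for the compounds shown here, dimethylamino in place of phenoxy on the aromatic carbon para to a large group gives a number 4 percentage points lower from compound 3 to compound 4 (within the scatter), the first step that can be read at this position. The position therefore accepts the exchange of a phenoxy group of 7 heavy atoms, with its six-membered aromatic ring, for a dimethylamino group of 3 heavy atoms and no ring, without the assay separating the two compounds at the concentration used. Nothing available bears on why this exchange leaves the two compounds unseparated.

Going by these compounds, whether a carboxylic acid or a morpholine ring at this place would give a step beyond the scatter remains open. On these data alone, the read-out at one concentration gives no potency, so it also remains open whether compound 3 and compound 4 would separate at higher concentrations.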